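Chalcone ketone-side aryl swap: bromophenyl back in

The compounds below may be only part of what the source reports. "The series", "measured", "known", "first", "only" and "open" are said of these compounds alone.

The measured pair:
compound 1 `O=C(/C=C/c1cccc(OCc2ccccc2)c1)c1ccc(Br)cc1` gives 6500 nM;
compound 2 `COc1ccc(C(=O)/C=C/c2cccc(OCc3ccccc3)c2)cc1` gives 6000 nM.

Both values come from a functional assay on MCF7 cells (Homo sapiens) for cytotoxicity, read by MTT assay, with a stated time of 68 h; on this read-out higher numbers stand for weaker inhibition and lower numbers for stronger inhibition. Compound 2 carries the lower of the two numbers, but the step of a 1.1-fold lower number from compound 1 to compound 2 (0.03 log units; within the scatter) is within the scatter, so the two compounds cannot be told apart on this read-out.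

Compound 3 `O=C(/C=C/c1cccc(OCc2ccccc2)c1)c1cccc(Br)c1` has not yet been measured in this assay. The change from compound 2 is 3-bromophenyl in place of 4-methoxyphenyl on a carbonyl carbon. Going by the values given here, the only measured step, from compound 1 to compound 2, concerns a methoxy in place of bromo on the same aromatic carbon and was within the scatter; no measured step shows what moving the bromine to a 3-bromophenyl does. There is therefore no basis for expecting a shift beyond the scatter, and the step of a 1.1-fold higher number from compound 2 to compound 3 (0.03 log units; within the scatter) is estimated to be small. Compound 3 is expected to give about 6500 nM, within a range of 2800 nM to 15000 nM.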

Compound 3, half-maximal inhibitory concentration: 7900 nM
The estimate for compound 3 lay 1.2-fold (0.08 log units) below the measured number; low and high end bracket the measured number.
By their numbers in this assay, from the lowest: compounds 2, 1 and 3 (each within the scatter of the next).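

In this assay the group on the carbonyl carbon now appears in three forms, and the step of a 1.3-fold higher number from compound 2 to compound 3 (0.12 log units; within the scatter) shows that 3-bromophenyl in place of 4-methoxyphenyl leaves the number within the scatter. The step of a 1.2-fold higher number from compound 1 to compound 3 (0.08 log units; within the scatter) adds what the earlier pair could not show: changing 4-bromophenyl to 3-bromophenyl, which keeps the bromine and changes only its place on the ring, also stays within the scatter. No evidence is available that bears on why these numbers lie so close together.

The compounds shown leave open whether any other group on this ring, such as an amine or a carboxylic acid, would move the number beyond the scatter. They also leave open whether a change elsewhere on the shared core would do so.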